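Aryl swap on an aromatic nitrogen: outlook for compound 3

A few compounds are considered here, and "the series" means these few. Any claim that something is new, unique, unknown or untested is made for them only; others in the source may bear on it.

Compound 1 `CCc1cccc(CC)c1-n1nncc1CN1C(=O)C2(C(C#N)=C(N)Oc3c(N)cc4nc5ccccc5nc4c32)c2ccccc21` and compound 2 `COc1ccc(OC)c(-n2nncc2CN2C(=O)C3(C(C#N)=C(N)Oc4c(N)cc5nc6ccccc6nc5c43)c3ccccc32)c1` share one core and differ only in the aryl group carried on an aromatic nitrogen. In an ADME assay on L02 cells (Homo sapiens) for antiproliferative activity, read by MTT assay, with a stated time of 48 h (on this read-out lower numbers stand for stronger inhibition and higher numbers for weaker inhibition), compound 1 gives > 50000 nM, a limit of the assay rather than a number. In this assay compound 2 gives > 50000 nM, again a limit. The step that the two limits leave unreadable from compound 1 to compound 2 is therefore unreadable. On the numbers shown compound 2 stands at the limit of > 50000 nM in this assay, at which 2 of the 2 values shown sit, with no measured compound giving a number.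

Compound 3 `N#CC1=C(N)Oc2c(N)cc3nc4ccccc4nc3c2C12C(=O)N(Cc1cnnn1-c1ccc([N+](=O)[O-])cc1[N+](=O)[O-])c1ccccc12` is not yet measured and differs from compound 2 by 2,4-dinitrophenyl in place of 2,5-dimethoxyphenyl on an aromatic nitrogen. Among the compounds with values here, the only measured step, a step that the two limits leave unreadable from compound 1 to compound 2, changes the same aryl group but has no readable size, so no direction or size in this assay can be derived from it. Compound 3 is expected to remain at the limit, with an expected step that the limit leaves unreadable from compound 2 to compound 3. For compound 3 the estimate is 60000 nM, ranging from 20000 nM to 200000 nM.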

Compound 3, half-maximal inhibitory concentration: 22800 nM
Beside the measured number, compound 3's estimate is 2.6-fold (0.42 log units) above it, and the stated range covers the measured number.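

In this assay, the aryl group on the aromatic nitrogen now proves able to move the read-out: 2,4-dinitrophenyl in place of 2,5-dimethoxyphenyl gives an at least 2.1-fold lower number from compound 2 to compound 3 (0.34 log units; beyond the scatter), and in place of 2,6-diethylphenyl it gives an at least 2.1-fold lower number from compound 1 to compound 3 (0.34 log units; beyond the scatter). Going by these compounds, both steps have a lower bound only, so their full size stays unknown, and the step between the two earlier compounds cannot be read. Compound 3 alone gives a number rather than a limit, while the rest of the set stays at one limit: the limit of > 50000 nM in this assay, at which 2 of the 3 values shown sit.

The compounds shown do not separate the contribution of the two nitro groups, since no aryl group here carries a single nitro group. Nor do they show whether an amine or a carboxylic acid on this phenyl ring would keep a measurable number in this assay.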